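The source may hold more compounds than are shown below. What is called first, only, known or untested is meant among the compounds shown, and "the series" means these compounds.

For the measured compounds named here, in a physicochemical assay for acid dissociation, compound 1 `COc1cccc(CNCCCNc2ccnc3cc(Oc4ccc(Cl)cc4)ccc23)c1O` gives 9.28, the lowest of the two numbers measured so far. Compound 2 `Fc1ccc(-c2ccc3c(NCCCNCc4ccco4)ccnc3c2)cc1` gives 9.47, a value that falls within the usual scatter of that of compound 1, so the two cannot be set apart. Compound 3 `COc1cccc(CNCCCNc2ccnc3cc(Oc4cccc(N(C)C)c4)ccc23)c1O` has not yet been measured in this assay. It differs from compound 1 by 3-(dimethylamino)phenyl in place of 4-chlorophenyl on an oxygen on an aromatic ring. Going by the values given here, no step between measured compounds is available for this kind of change; the account therefore expects a step of no more than the scatter, in either direction, which is estimated as a number 0.02 log units higher from compound 1 to compound 3 (within the scatter). For compound 3 the estimated value is 9.3, expected to lie between 8.95 and 9.65.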

Compound 3, acid dissociation constant: 9.28
The estimate for compound 3 lay 0.02 log units above the measured number; the measured number falls inside the stated range.
By their numbers in this assay, from the lowest: compounds 1, 3 and 2 (each within the scatter of the next).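

In this assay, for the compounds shown here, 3-(dimethylamino)phenyl in place of 4-chlorophenyl gives no change at the digits printed from compound 1 to compound 3 (within the scatter) and so gives the first reading of a change at this place. The entering group carries nitrogen and a hydrogen-bond acceptor, whereas the leaving group carries chlorine, yet the step stays within the scatter. Nothing available accounts for this result. From the compounds shown here alone, it remains open whether a carboxylic acid or a primary amine on the same phenyl ring would leave the number equally undisturbed. Going by these compounds, a longer chain between the shared core and the aromatic ring also remains untested in these compounds.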